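Adding One More Hydroxy Group to a Diketone Core

The source may hold more compounds than are shown below. What is called first, only, known or untested is meant among the compounds shown, and "the series" means these compounds.

Three compounds have been measured in an ADME assay on PC-12 cells (Rattus norvegicus) for cytotoxicity, read by WST assay, with a stated time of 24 h; a lower number here means that less compound is tolerated, a higher number that more compound is tolerated:

Compound 1, `O=C(/C=C/c1cccc(O)c1O)CC(=O)/C=C/c1cccc(O)c1O`, gives 39000 nM.
Compound 2, `O=C(/C=C/c1cccc(O)c1)CC(=O)/C=C/c1cccc(O)c1O`, gives 38000 nM.
Compound 3, `O=C(/C=C/c1cccc(O)c1)CC(=O)c1ccc(O)c(O)c1`, gives > 100000 nM, which is a limit of the assay and not a number.

Compound 1 differs from compound 2 by hydroxy in place of hydrogen on an aromatic carbon, and this change gave a 1.0-fold higher number from compound 2 to compound 1 (0.01 log units; within the scatter). The difference between the core of compound 2 and the core of compound 3 is not broken down here. Compound 3 sits at the limit of > 100000 nM in this assay, at which 1 of the 3 values shown sits.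

Compound 4, `O=C(/C=C/c1cc(O)ccc1O)CC(=O)c1ccc(O)c(O)c1`, has not yet been measured. It differs from compound 3 by hydroxy in place of hydrogen on an aromatic carbon. Among the compounds with values here, this is the same kind of change as the one from compound 2 to compound 1, though not the same: there the entering hydroxy sat ortho to a hydroxy group and ortho to a large group, whereas in compound 4 it sits ortho to a large group and para to a hydroxy group.

Within the data shown here, because the one measured example of this kind of change, a 1.0-fold higher number from compound 2 to compound 1 (0.01 log units; within the scatter), stayed within the scatter, the step from compound 3 to compound 4 is expected to be small as well, a number no higher from compound 3 to compound 4 (the limit leaves the size open). Compound 4 is therefore estimated at 100000 nM, with a likely range from 40000 nM to 250000 nM, and there is a fair chance that compound 4 is again reported only as a limit.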

Compound 4, half-maximal cytotoxic concentration: > 100000 nM
Compound 4: no number, only a limit; the forecaster's own chance of this, stated with the estimate: 60%; the middle value lies on the limit itself.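

Within the data shown here, compound 3 and compound 4 are each reported in this assay only as a limit and not as a number, so no step between them can be read: the limit of > 100000 nM in this assay, at which 2 of the 4 values shown sit. The compounds shown leave open what number either compound would have, and so whether hydroxy in place of hydrogen on this aromatic carbon changes the result for this pair at all.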